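Chain extension on two cores in an antiproliferative assay

A few compounds are considered here, and "the series" means these few. Any claim that something is new, unique, unknown or untested is made for them only; others in the source may bear on it.

Measured compounds:
compound 1 `CCCCNS(=O)(=O)c1ccc(Nc2ncc3c(n2)N(C2CCCC2)[C@H](CC)C(=O)N3C)cc1` gives 477 nM in a functional assay on A549 cells (Homo sapiens) for antiproliferative activity, read by CCK-8 assay, with a stated time of 72 h; on this read-out higher numbers stand for weaker inhibition of growth and lower numbers for stronger inhibition of growth
compound 2 `CCCNS(=O)(=O)c1ccc(Nc2ncc3c(n2)N(C2CCCC2)[C@H](CC)C(=O)N3C)cc1` gives 563 nM in this assay
compound 3 `CCCNC(=O)c1ccc2c(ccn2-c2ncc3c(n2)N(c2ccn(C)n2)C(CC)C(=O)N3C)c1` is reported as "not active" (no number reported) in this assay, with no number given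

Compounds 1 and 2 share one core, compounds 3 and 4 another; how the two cores differ is not broken down here. Between compound 2 and compound 1 the change is methyl in place of hydrogen on a saturated chain carbon, three bonds along the chain from a sulfonamide nitrogen, and it gave a 1.2-fold lower number from compound 2 to compound 1 (0.07 log units; within the scatter). Compound 4 `CCCCNC(=O)c1ccc2c(ccn2-c2ncc3c(n2)N(c2ccn(C)n2)C(CC)C(=O)N3C)c1` carries the same kind of change relative to compound 3, (methyl in place of hydrogen on a saturated chain carbon, three bonds along the chain from an amide-type nitrogen); the two places differ in that the chain of compound 1 runs to a sulfonamide nitrogen, while that of compound 4 runs to an amide-type nitrogen. Within the data shown here, the only measured instance of this change, from compound 2 to compound 1, stayed within the scatter, so the step from compound 3 to compound 4 in this assay is expected to be of similar small size, resting on a 1.2-fold lower number from compound 2 to compound 1 (0.07 log units; within the scatter). Since compound 3 has no number, the expectation for compound 4 rests on that report of inactivity. Compound 4 is therefore expected to remain weak, around 30000 nM, most likely between 8000 nM and 100000 nM, with a real chance that again only a limit is reported.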

Compound 4, concentration for 50% growth inhibition: 37300 nM
Estimate against measurement, compound 4: 1.2-fold (0.09 log units) below; the measured number falls inside the stated range.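

In this assay, among these compounds, compound 3 has only a report of inactivity, so no step to compound 4, at 37300 nM, can be read. No supporting data bear on this result. The compounds shown leave open whether going from propyl to butyl changes growth inhibition on the core of compound 3.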